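The compounds below may be only part of what the source reports. "The series", "measured", "known", "first", "only" and "open" are said of these compounds alone.

Measured so far in a functional assay on HFF cells (Homo sapiens) for cytotoxicity; on this read-out lower numbers stand for stronger inhibition and higher numbers for weaker inhibition:
- compound 1 `COC[C@H]1O[C@@H](n2c(Cl)nc3cc(Cl)c(Cl)cc32)[C@H](OC(C)=O)[C@@H]1OC(C)=O` gives 26000 nM
- compound 2 `CCOC[C@H]1O[C@@H](n2c(Cl)nc3cc(Cl)c(Cl)cc32)[C@H](OC(C)=O)[C@@H]1OC(C)=O` gives 33000 nM
- compound 3 `CC(=O)OC1C(CCl)OC(n2c(Cl)nc3cc(Cl)c(Cl)cc32)C1OC(C)=O` gives 32000 nM

On these numbers, compound 3 stands within the usual scatter of both compound 1 and compound 2, so the three cannot be told apart. The next compound, compound 4 `CC(=O)OC1C(CN=[N+]=[N-])OC(n2c(Cl)nc3cc(Cl)c(Cl)cc32)C1OC(C)=O`, differs from compound 3 by azido in place of chloro on a saturated chain carbon bound to a saturated ring carbon. Going by the values given here, no measured step covers this exact change. The nearest evidence is a 1.3-fold higher number from compound 1 to compound 2 (0.10 log units; within the scatter), which lies within the scatter. A change in this assay beyond the scatter is therefore not expected, and the expected step is a 1.1-fold lower number from compound 3 to compound 4 (0.03 log units; within the scatter). For compound 4 the estimated value is 30000 nM, with an expected range from 13000 nM to 70000 nM.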

Compound 4, half-maximal inhibitory concentration: 32000 nM
Compound 4: the middle estimate sits 1.1-fold (0.03 log units) below what was measured, and the stated range covers the measured number.
By their numbers in this assay, from the lowest: compounds 1, 3, 4 and 2 (each within the scatter of the next).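

In this assay, chloromethyl to azidomethyl gives no change at the digits printed from compound 3 to compound 4 (within the scatter), so on this saturated chain carbon bound to a saturated ring carbon, a group of three heavy atoms can replace one of a single heavy atom with no shift beyond the scatter. Going by these compounds alone, the only earlier step was a methyl in place of a hydrogen at a different place, so this position had not been probed. Nothing available explains the result. Open, as far as these compounds go, is whether an amine or a carboxylic acid at this position would also stay within the scatter.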